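Acylation of the ring nitrogen: propanoyl analogue of compound 3

This account rests on a few compounds, and the source may have more. Where it says the series, first, only, none or still open, it means among the compounds named here.

Compound 3 `O=C(Nc1ccccc1C(F)(F)F)C1CCc2ccccc2N1` gives 53300 nM in a functional assay on PC-3 cells (Homo sapiens) for cytotoxicity, read by sulforhodamine B assay, with a stated time of 72 h (a higher number here means a weaker inhibitor of growth, a lower number a stronger inhibitor of growth), the highest of the two numbers obtained; the nearest is compound 2 `CCCCCCCCC(=O)N1c2ccccc2CCC1C(=O)Nc1ccccc1C(F)(F)F` with 4320 nM, and the step of a 12-fold higher number from compound 2 to compound 3 (1.09 log units; beyond the scatter). Compound 1 `CCCC(=O)N1c2ccccc2CCC1C(=O)Nc1ccccc1C(F)(F)F` sits at a limit, > 70000 nM (the limit of > 70000 nM in this assay, at which 1 of the 3 values shown sits). From compound 1 an at least 16-fold lower number from compound 1 to compound 2 (1.20 log units; beyond the scatter), while an at least 1.3-fold lower number from compound 1 to compound 3 (0.11 log units; that floor lies within the scatter). Compound 4 `CCC(=O)N1c2ccccc2CCC1C(=O)Nc1ccccc1C(F)(F)F` carries the change (propanoyl in place of hydrogen on a nitrogen on an aromatic ring in a ring), a shorter acyl group than in compound 1. The steps bearing on it, the large one from compound 2 and the within-scatter one from compound 1, indicate that a short acyl chain gives no gain; the step of a 1.3-fold higher number from compound 3 to compound 4 (0.12 log units; within the scatter) is expected to stay within the scatter or tend higher. Compound 4 is therefore estimated at 70000 nM, between 30000 nM and 200000 nM.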

Compound 4, concentration for 50% growth inhibition: > 80000 nM
Compound 4: a limit, no number; the forecaster's own chance of this, stated with the estimate: 55%; middle value at least 1.1-fold (0.05 log units) away from the limit.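

In this assay compound 4 sits at a limit, not a number: the limit of > 80000 nM in this assay, at which 1 of the 4 values shown sits. Propanoyl on the nitrogen gives an at least 1.5-fold higher number from compound 3 to compound 4 (0.17 log units; that floor lies within the scatter), so no gain over the free nitrogen appears, while an at least 18-fold higher number from compound 2 to compound 4 (1.26 log units; beyond the scatter) sets the octylcarbonyl group apart from this short acyl group, as it does from the propylcarbonyl group of compound 1. The step between the two short acyl compounds cannot be read, since both are limits. Open, as far as these compounds go, is the chain length at which the gain begins, and whether a longer chain or an acyl group ending in an amine keeps it.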